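This account rests on a few compounds, and the source may have more. Where it says the series, first, only, none or still open, it means among the compounds named here.

In an assay on microsomes from brain for inhibition of Fatty-acid amide hydrolase 1 (Rattus norvegicus), read by fluorescence and HPLC, with a stated time of 60 min (on this read-out lower numbers stand for stronger inhibition and higher numbers for weaker inhibition), compound 1 `CC(Oc1ccc(Oc2ccc(F)cc2)cc1)C(=O)Cn1nnc(-c2ccccc2)n1` gives 24 nM, and compound 2 `CC(Oc1ccc(Oc2ccc(Cl)cc2)cc1)C(=O)Cn1nnc(-c2ccccc2)n1` gives 51 nM. Within the data shown here, compound 2 thus holds the higher of the two numbers; the only measured step, a 2.1-fold higher number from compound 1 to compound 2 (0.33 log units; beyond the scatter), is a modest weakening. Compound 3 `CC(Oc1ccc(Oc2ccc(C(F)(F)F)cc2)cc1)C(=O)Cn1nnc(-c2ccccc2)n1` carries the change (trifluoromethyl in place of chloro on an aromatic carbon). Among the measured compounds shown here, only the step from compound 1 to compound 2 bears on this, a change at the same place, and it was small. A further modest rise in this assay is therefore expected for compound 3, estimated at 75 nM with a range of 25 nM to 220 nM. The expected step is a 1.5-fold higher number from compound 2 to compound 3 (0.17 log units; within the scatter).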

Compound 3, half-maximal inhibitory concentration: 160 nM
The estimate for compound 3 lay 2.1-fold (0.33 log units) below the measured number, within the range that was stated.
By their numbers in this assay, from the lowest: compound 1; then compound 2; then compound 3.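

In this assay, trifluoromethyl in place of chloro gives a 3.1-fold higher number from compound 2 to compound 3 (0.50 log units; beyond the scatter), so the rise seen on going from fluoro to chloro continues past chloro and does not level off. Across the three groups at this place, the change amounts to a 6.7-fold higher number from compound 1 to compound 3 (0.82 log units; beyond the scatter), showing that this position responds clearly to the choice of group and that no compound here goes against the order fluoro, chloro, trifluoromethyl. Nothing available accounts for this order.

Open, as far as these compounds go, is how a methoxy group, an amine or a carboxylic acid at this place would compare. Also open, from the compounds shown here alone, is whether the same order would hold with changes elsewhere on the shared core.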